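The source may hold more compounds than are shown below. What is called first, only, known or untested is meant among the compounds shown, and "the series" means these compounds.

Measured so far:
- Compound 1 `O=C(NCc1ccc2cccnc2c1O)C1CCCCC1`: 720 nM
- Compound 2 `CCCC(=O)NC(c1ccc(C)cc1)c1cc(Cl)c2cccnc2c1O`: 100 nM

Both compounds were tested in a functional assay on Daoy cells (Homo sapiens) for antiproliferative activity, read by trypan blue exclusion and crystal violet staining, with a stated time of 72 h; a lower number here means a stronger inhibitor, a higher number a weaker inhibitor. Compound 2, at 100 nM, has the lower of the two numbers, so it is the stronger inhibitor of the pair, and its gap to compound 1 lies beyond the scatter. These two compounds differ in more than one place, so that gap reveals nothing about any single group.

The next compound is compound 3 `CCCC(=O)NC(c1ccc(Cl)cc1)c1cc(Cl)c2cccnc2c1O`. It keeps all of compound 2 except for one swap, 4-methylphenyl to 4-chlorophenyl: chloro in place of methyl on an aromatic carbon.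

For the measured compounds named here, no measured pair isolates a change in one place, so there is no direct precedent for this swap. The expectation therefore starts from compound 2 at 100 nM and rests on how small the exchange is, one heavy atom for another.

In this assay, the expected change is a 1.1-fold lower number from compound 2 to compound 3 (0.05 log units; within the scatter), which would be no shift beyond the scatter. For compound 3, the estimated value is 90 nM, with an expected range of 35 nM to 230 nM.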

Compound 3, half-maximal inhibitory concentration: 100 nM
For compound 3 the middle estimate is 1.1-fold (0.05 log units) below the measured one, within the range that was stated.
By their numbers in this assay, from the lowest: compounds 2 and 3 (each within the scatter of the next); then compound 1.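

In this assay, for the compounds shown here, putting chloro in place of methyl on the aromatic ring gives no change at the digits printed from compound 2 to compound 3 (within the scatter), and this is the first reading of a single change, since the two earlier compounds differ in more than one place. It shows that this position, on a six-membered aromatic ring of carbon only and para to a large group, can carry either of these two groups with no shift beyond the scatter, at least in this pair of compounds. No measurement shown here explains why the two groups give the same reading.

Both groups hold a single heavy atom and no hydrogen-bond donors or acceptors, so the compounds shown leave open what a hydroxyl, an amine or a carboxylic acid would do at this position. Also open, going by these compounds, is whether a longer chain on the amide would leave this swap just as silent, and which of the several differences separates compound 1 from compound 2 and compound 3.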